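A few compounds are considered here, and "the series" means these few. Any claim that something is new, unique, unknown or untested is made for them only; others in the source may bear on it.

Compound 1, `CCCOC(=O)C1=C(C)NC(=S)NC1c1ccco1`, gives 1% in an assay on membranes from HeLa cells for displacement of a labelled ligand from adenosine receptor A3 (Homo sapiens), read by scintillation counting, with a stated time of 180 min, tested at 1 uM; on this read-out higher numbers stand for more inhibition at the one concentration tested (going by the name of the read-out) and lower numbers for less inhibition. Compound 2, `CC1=C(C(=O)OCC(C)C)C(c2ccco2)NC(=S)N1`, carries the change methyl in place of hydrogen on a saturated chain carbon bound to two saturated chain carbons relative to compound 1, and in this assay compound 2 gives 10%, which makes a number 9 percentage points higher from compound 1 to compound 2 (within the scatter). Compound 3, `CCCOC(=O)C1=C(C)N(C)C(=O)NC1c1ccsc1`, rests on a different core, and the difference between the two cores is not broken down here; in this assay compound 3 gives 11%. Compound 4, `CC1=C(C(=O)OCC(C)C)C(c2ccsc2)NC(=O)N1C`, has not been measured; it differs from compound 3 by methyl in place of hydrogen on a saturated chain carbon bound to two saturated chain carbons, the same change as that between compound 1 and compound 2, at the same place. Because the earlier change gave only a number 9 percentage points higher from compound 1 to compound 2 (within the scatter), a step of similar size, a number 5 percentage points higher from compound 3 to compound 4 (within the scatter), is expected for compound 4. Compound 4 is therefore estimated at 16%, expected to lie between 0% and 33%.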

Compound 4, a percentage reported as inhibition, at one concentration (the size of the read-out at that concentration, not a potency): 4%
Compound 4: the middle estimate sits 12 percentage points above what was measured; the range from low to high includes it.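

In this assay the change from propoxy to isobutoxy on the core of compound 3 comes out as a number 7 percentage points lower from compound 3 to compound 4 (within the scatter). Set beside the step on the core of compound 1, the change does not carry over as a fixed increment between these two cores: the same change on two cores in this assay, a number 9 percentage points higher (within the scatter) from compound 1 to compound 2 and a number 7 percentage points lower (within the scatter) from compound 3 to compound 4, 16 percentage points apart, beyond the scatter of two such steps This rests on a single pair per core, each step taken alone lies within the scatter, and the comparison does not show which difference between the cores goes with the gap.

The compounds shown leave open how a longer chain such as butoxy, or a carboxylic acid in place of the ester, would read in this assay. They also leave open how the same change would read on any further core.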